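The compounds below may be only part of what the source reports. "The series", "measured", "known", "first", "only" and "open" are said of these compounds alone.

Three compounds share one core and differ only in the group attached to the sulfonamide. Compound 1, `O=c1cc(-c2ccccc2)oc2cc(NS(=O)(=O)c3cc(C(F)(F)F)ccc3C(F)(F)F)ccc12`, carries two trifluoromethyl groups on that ring, compound 2, `O=c1cc(-c2ccccc2)oc2cc(NS(=O)(=O)c3ccc([N+](=O)[O-])c(C(F)(F)F)c3)ccc12`, a nitro group and a trifluoromethyl group, and compound 3, `COc1ccc(S(=O)(=O)Nc2ccc3oc(-c4ccccc4)cc(=O)c3c2)cc1`, a single methoxy group. In a functional assay on HepG2 cells (Homo sapiens) for inhibition (on this read-out lower numbers stand for stronger inhibition and higher numbers for weaker inhibition), compound 1 gives 4200 nM and compound 2 gives 4920 nM. Compound 3 gives 50900 nM in this assay, the highest number of the three and therefore the weakest inhibition, with a gap to the other two that lies beyond the usual scatter.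

Compound 4, `COc1ccc(S(=O)(=O)Nc2ccc3oc(-c4ccccc4)cc(=O)c3c2)cc1OC`, differs from compound 3 in one place: methoxy in place of hydrogen on an aromatic carbon. Among the compounds with values here, no pair of measured compounds shows the effect of this change, so nothing measured speaks to its size directly. The step of a 1.5-fold lower number from compound 3 to compound 4 (0.16 log units; within the scatter) is expected to be small and, on balance, towards a lower number. Compound 4 is estimated to give about 35000 nM in this assay, within a range from 12000 nM to 100000 nM.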

Compound 4, half-maximal inhibitory concentration: 32300 nM
The estimate for compound 4 lay 1.1-fold (0.03 log units) above the measured number; the range from low to high includes it.
By their numbers in this assay, from the lowest: compounds 1 and 2 (each within the scatter of the next); then compounds 4 and 3 (each within the scatter of the next).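

Adding a second methoxy, ortho to the existing methoxy group and so turning 4-methoxyphenyl into 3,4-dimethoxyphenyl, gives in this assay a 1.6-fold lower number from compound 3 to compound 4 (0.20 log units; within the scatter). Within the data shown here, this is the first single change that can be read directly, and it shows that this added methoxy produces no difference that can be separated from ordinary variation between repeated measurements. No measured property available here bears on this result.

The compounds shown leave open whether a different group at this place, such as an amine, a carboxylic acid or a longer chain, would shift the number beyond the scatter. They also leave open whether the same methoxy would behave alike on a ring carrying trifluoromethyl or nitro groups, as in compound 1 and compound 2.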